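The compounds below may be only part of what the source reports. "The series", "measured", "known", "first", "only" and "open" are said of these compounds alone.

In a functional assay on PC-9 cells (Homo sapiens) for inhibition, read by MTT assay, with a stated time of 48 h, tested at 10 uM (a higher number here means more inhibition at the concentration tested (going by the name of the read-out), a lower number less inhibition), the measured compounds read:

compound 1 `COc1cc(NC(=O)Nc2cc(Nc3cc(Br)ccc3OC)ncn2)cc(OC)c1` — 82.5%
compound 2 `CCc1cccc(Nc2cc(NC(=O)Nc3cc(OC)cc(OC)c3)ncn2)c1` — 82.1%
compound 3 `COc1cc(NC(=O)Nc2cc(Nc3ccc(Br)cc3OC)ncn2)cc(OC)c1` — 83%

Compound 3 holds the highest of the three numbers, but only nominally: one gap is a number 0.5 percentage points higher from compound 1 to compound 3 (within the scatter) and the other gap is a number 0.9 percentage points higher from compound 2 to compound 3 (within the scatter), both within the scatter, so the three compounds cannot be separated.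

The next step keeps the shared core of compound 3 and exchanges the aryl group on the nitrogen: 3,4-dimethylphenyl in place of 4-bromo-2-methoxyphenyl on a nitrogen on an aromatic ring. Compound 4 is `COc1cc(NC(=O)Nc2cc(Nc3ccc(C)c(C)c3)ncn2)cc(OC)c1`.

All three measured steps vary this same aryl group. Going by the values given here, the closest precedent is the exchange of a bromo-methoxyphenyl for an alkyl-bearing phenyl, which gave a number 0.4 percentage points lower from compound 1 to compound 2 (within the scatter); the reverse kind of exchange gave a number 0.9 percentage points higher from compound 2 to compound 3 (within the scatter); moving the bromine gave a number 0.5 percentage points higher from compound 1 to compound 3 (within the scatter). None of these left the scatter. A dimethylphenyl is a change of the same kind as the ethylphenyl in compound 2, so no step beyond the scatter is expected in this assay .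

The estimate for compound 4 is therefore 82%, range 72% to 90%, which means an expected step of a number 1 percentage points lower from compound 3 to compound 4 (within the scatter).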

Compound 4, a percentage reported as inhibition, at one concentration (the size of the read-out at that concentration, not a potency): 66%
The estimate for compound 4 lay 16 percentage points above the measured number; measured number outside the range, below it.
By their numbers in this assay, from the lowest: compound 4; then compounds 2, 1 and 3 (each within the scatter of the next).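

Going by these compounds alone, this aryl position on the nitrogen is not indifferent to substitution in this assay: the 3,4-dimethylphenyl group gives the first step beyond the scatter, with a number 17 percentage points lower from compound 3 to compound 4 (beyond the scatter) and, against the other two aryl groups, a number 16.1 percentage points lower from compound 2 to compound 4 (beyond the scatter) and a number 16.5 percentage points lower from compound 1 to compound 4 (beyond the scatter). An alkyl-bearing phenyl as such does not account for the separation, as compound 2 with its 3-ethylphenyl group stays within the scatter of compound 1 and compound 3, while compound 4 does not. No measurement shown gives a reason for this step.

From the compounds shown here alone, it remains open whether the step goes with either methyl group alone, which a 3-methylphenyl or a 4-methylphenyl group on the same nitrogen would address. Also open, going by these compounds, is how a 4-bromophenyl group without the methoxy reads at this position.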